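This account rests on a few compounds, and the source may have more. Where it says the series, first, only, none or still open, it means among the compounds named here.

Working notes on the series. Among the measured compounds shown here, compound 1 `COc1cc(/C=C/C(C)=O)ccc1OCc1cn(-c2ccnc3cc(Cl)ccc23)nn1` is one of three compounds measured in an in vitro ADME assay on microsomes from liver (Homo sapiens) for metabolic stability, read by LC-MS, using NADPH, tested at 1 uM, in the presence of a further agent that is not named here; on this read-out lower numbers stand for a shorter-lived compound and higher numbers for a longer-lived compound; in this assay compound 1 gives 0.123 h, the lowest of the three numbers. Compound 3 `COc1cc(/C=C/C(C)=O)ccc1OCCNc1ccnc2cc(Cl)ccc12` gives 0.175 h in this assay, which lies within the scatter of compound 1. Compound 2 `COc1ccc(C(=O)/C=C/c2cc(CN3CCN(c4ccnc5cc(Cl)ccc45)CC3)c(O)c(OC)c2)c(OC)c1` gives 0.617 h in this assay, beyond the scatter from compound 1, but compound 2 differs from compound 1 in several places at once. Compound 4 `COc1ccc(C(=O)/C=C/c2ccc(OCc3cn(-c4ccnc5cc(Cl)ccc45)nn3)c(OC)c2)c(OC)c1` is not yet measured. The change from compound 1 is 2,4-dimethoxyphenyl in place of methyl on a carbonyl carbon. For the measured compounds named here, no single-point step covers this change, so the expectation for compound 4 in this assay is a modest rise, a 2.0-fold higher number from compound 1 to compound 4 (0.31 log units; beyond the scatter), with the range open to no change beyond the scatter. Compound 4 is estimated at 0.25 h, between 0.08 h and 0.8 h.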

Compound 4, half-life in the Homo sapiens assay: 0.852 h
Compound 4: the middle estimate sits 3.4-fold (0.53 log units) below what was measured, outside the stated range (above it).
By their numbers in the Homo sapiens assay, from the lowest: compounds 1 and 3 (each within the scatter of the next); then compounds 2 and 4 (each within the scatter of the next).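

In the Homo sapiens assay, 2,4-dimethoxyphenyl in place of methyl on a carbonyl carbon gives a 6.9-fold higher number from compound 1 to compound 4 (0.84 log units; beyond the scatter), so this position accepts a much larger group, with an aromatic ring, and the half-life lengthens rather than shortens. The longer half-life does not come with lower lipophilicity in a physicochemical assay for lipophilicity, read by HPLC, at pH 7.4 (a higher number here means a more lipophilic compound, a lower number a more polar compound), where compound 1 gives 3.6 and compound 4 gives 4.3: the measured distribution coefficient of compound 1, 3.6, and of compound 4, 4.3, a number 0.70 log units higher (beyond the scatter)

On these data alone, whether the ring alone or its methoxy groups carry the rise stays open, since phenyl without methoxy groups or a chain ending in an amine on this carbonyl carbon does not appear here. Also open, as far as these compounds go, is whether the same change lengthens the half-life on the core of compound 3.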